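The source may report more compounds than this note shows. Statements on the series, on what has been measured and on what is new or still open speak of the compounds shown alone.

In an ADME assay on HepG2 2.2.15 cells (Homo sapiens) for cytotoxicity, read by MTT assay (a higher number here means that more compound is tolerated, a lower number that less compound is tolerated), compound 2 `COc1cc(C(=O)Oc2ccc(C(C)=O)cc2)cc(OC)c1OC` gives 1210000 nM as a true number. Compound 1 `COc1ccc(/C=C/C(=O)Oc2ccc(C(C)=O)cc2)cc1` stands at > 3270000 nM which is a limit and not a number. Compound 3 `COc1cccc(/C=C/C(=O)OC[C@H]2O[C@@H](Oc3ccc(C(C)=O)cc3)[C@H](O)[C@@H](O)[C@@H]2O)c1` stands at > 1510000 nM which is again only a limit, so its exact place is open. From the compounds shown here alone, compound 4 `CC(=O)c1ccc(O[C@@H]2O[C@H](COC(=O)c3cccnc3)[C@@H](O)[C@H](O)[C@H]2O)cc1` carries pyridin-3-yl in place of 2-(3-methoxyphenyl)ethenyl on a carbonyl carbon and is still untested. Among the measured compounds shown here, no measured pair differs in one place, so there is no direct guide to this swap. The step that the limit leaves unreadable from compound 3 to compound 4 is expected to stay within the usual scatter, with no firm direction. For compound 4 the estimated value is 2000000 nM with an expected range from 800000 nM to 4000000 nM in this assay.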

Compound 4, half-maximal cytotoxic concentration: > 1650000 nM
Compound 4: a limit, no number; the forecaster's own chance of this, stated with the estimate: 60%; the middle value is on the limit's open side.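

Among the compounds shown here, compound 3 and compound 4 both give only limits in this assay, so no step between them can be read. The compounds shown leave open whether pyridin-3-yl in place of 2-(3-methoxyphenyl)ethenyl changes how much compound is tolerated.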